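The source may report more compounds than this note shows. Statements on the series, on what has been measured and on what is new or still open speak of the compounds shown alone.

Compound 2, `O=C(NCc1ccc(F)cc1)c1nc(Br)c2cccnc2c1NCc1ccccc1`, was tested in a functional assay on HCT-116 cells (Homo sapiens) for cytotoxicity, read by MTT assay, with a stated time of 72 h (a higher number here means a weaker inhibitor, a lower number a stronger inhibitor), alongside compound 1, `O=C(NCc1ccc(F)cc1)c1nc(Br)c2cccnc2c1NCCCNc1c(C(=O)NCc2ccc(F)cc2)nc(Br)c2cccnc12`. In this assay compound 2 gives > 20000 nM, which is a limit of the assay and not a number. Compound 1 likewise reaches only a limit in this assay, > 20000 nM. Among the measured compounds shown here, both measured values sit at the limit of > 20000 nM in this assay, at which 2 of the 2 values shown sit, so neither compound shows measurable inhibition here and no step between measured compounds can be drawn. Compound 3, `Nc1cccc(Nc2c(C(=O)NCc3ccc(F)cc3)nc(Br)c3cccnc23)c1`, has not yet been measured in this assay. It differs from compound 2 in one place: 3-aminophenyl in place of benzyl on a nitrogen on an aromatic ring. For the measured compounds named here, with both measured compounds resting at the limit, there is no measured step on which to base a direction for this change, and a substantial gain in potency would be needed before compound 3 returned a number at all. The step expected in this assay is an at least 1.3-fold lower number from compound 2 to compound 3 (0.12 log units; that floor lies within the scatter), in all likelihood none beyond the usual scatter. Compound 3 is estimated at 15000 nM, with a range from 4000 nM to 40000 nM.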

Compound 3, half-maximal inhibitory concentration: > 10000 nM
Compound 3: only a limit was reported; the forecaster's own chance of this, stated with the estimate: 60%; the middle value lies beyond the limit too.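

In this assay compound 3 gives > 10000 nM as a limit of the assay and not a number. Compound 2 gives > 20000 nM as a limit too. Among the compounds shown here, no step from compound 2 to compound 3 can be read from these two limits. The compounds shown leave open whether 3-aminophenyl in place of benzyl changes anything, and whether any of them would return a number in this assay at all.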